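A Saturated Branched Chain in Place of an Aromatic Ring

The compounds below may be only part of what the source reports. "The series", "measured", "known", "first", "only" and "open" are said of these compounds alone.

In an in vitro functional assay on cells for agonist activity at Bombesin receptor subtype-3 (Mus musculus), read by luminescence and calcium flux (a lower number here means that less compound is needed, a higher number that more compound is needed for the effect), compound 2 `Cc1ccccc1Cc1cnc(CCc2ccc(-c3ccccc3C(=O)O)cc2)[nH]1` gives 9.3 nM, the second highest of three numbers. Compound 1 `O=C(O)c1ccccc1-c1ccc(CCc2ncc(CC3CCCCC3)[nH]2)cc1` gives 7.3 nM, and a 1.3-fold higher number from compound 1 to compound 2 (0.11 log units; within the scatter). Compound 3 `O=C(O)c1ccccc1-c1ccc(CCc2ncc(CCc3ccccc3)[nH]2)cc1` gives 174 nM, and a 19-fold higher number from compound 2 to compound 3 (1.27 log units; beyond the scatter); likewise a 24-fold higher number from compound 1 to compound 3 (1.38 log units; beyond the scatter). Compound 4 `CC(C)(C)CCc1cnc(CCc2ccc(-c3ccccc3C(=O)O)cc2)[nH]1` differs from compound 2 in one place: neopentyl in place of 2-methylphenyl on a saturated chain carbon bound to an aromatic carbon. The step from compound 1 to compound 2 shows that cyclohexyl and 2-methylphenyl give similar numbers, whereas the steps to compound 3 show that benzyl costs much. Neopentyl has no ring and is saturated like cyclohexyl, so a step of modest size is expected, its direction uncertain. Compound 4 is therefore expected to give 25 nM (range 6 nM to 100 nM), meaning a 2.7-fold higher number from compound 2 to compound 4 (0.43 log units; beyond the scatter).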

Compound 4, half-maximal effective concentration: 6.2 nM
Beside the measured number, compound 4's estimate is 4.0-fold (0.61 log units) above it; measured number inside the range.
By their numbers in this assay, from the lowest: compounds 4, 1 and 2 (each within the scatter of the next); then compound 3.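

In this assay, neopentyl carries no ring, yet the change gives a 1.5-fold lower number from compound 2 to compound 4 (0.18 log units; within the scatter) and a 1.2-fold lower number from compound 1 to compound 4 (0.07 log units; within the scatter), so among these compounds a ring is not needed at this position. With tert-butyl in place of phenyl on a saturated chain carbon, two bonds along the chain from an aromatic carbon, the result is a 28-fold lower number from compound 3 to compound 4 (1.45 log units; beyond the scatter), so that chain does not by itself bring the high number of compound 3. Nothing available explains the gap between phenyl and tert-butyl. On these data alone, whether an amine at the end of the chain, or a longer chain, would fit equally well remains open.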